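The source may hold more compounds than are shown below. What is called first, only, known or untested is meant among the compounds shown, and "the series" means these compounds.

Measured so far:
- compound 1, `COc1cc(OC)c(OC)cc1/C=C/C1CC=CC(=O)O1`: 9.4 uM
- compound 2, `COc1ccc(/C=C/C2CC=CC(=O)N2)c(OC)c1`: > 964 uM
- compound 3, `COc1ccc(/C=C/C2CC=CC(=O)N2)cc1OC`: > 964 uM

In a functional assay on NCI/ADR cells (Homo sapiens) for inhibition, read by sulforhodamine B assay, with a stated time of 48 h (a higher number here means a weaker inhibitor of growth, a lower number a stronger inhibitor of growth), compound 1 gives 9.4 uM. Going by the values given here, compound 2 and compound 3 share one core but differ from compound 1 in more than one place, so no single step links them to it. For compound 3 this assay reports only a limit, > 964 uM, not a number. For compound 2 the same limit, > 964 uM, is reported. Compound 3 therefore stands at the limit of > 964 uM in this assay, at which 2 of the 3 values shown sit, and nothing closer can be said about where it would fall if the assay could read further.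

Compound 4, `COc1cc(OC)c(OC)cc1/C=C/C1CC=CC(=O)N1`, is compound 3 with one change: methoxy in place of hydrogen on an aromatic carbon. Among the compounds with values here, no measured pair shows this exact step, so the size of its effect in this assay is open. Because compound 3 sits at > 964 uM and compound 2 also gives > 964 uM, the starting point is itself only a limit, and the most likely outcome is that compound 4 also reaches only that limit. The step from compound 3 to compound 4 is expected to be an at least 1.9-fold lower number from compound 3 to compound 4 (0.28 log units; that floor lies within the scatter), with a wide range. Compound 4 is estimated at 500 uM, between 60 uM and 3000 uM.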

Compound 4, concentration for growth inhibition (reported as GI): > 864 uM
Compound 4: only a limit was reported; the forecaster's own chance of this, stated with the estimate: 60%; middle value at least 1.7-fold (0.23 log units) away from the limit.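

In this assay compound 4 gives only a limit, > 864 uM, not a number. Adding methoxy in place of hydrogen on this aromatic carbon therefore does not bring the nitrogen-containing compounds to a readable value, and the steps to compound 4 from compound 2 and compound 3 cannot be read, as both ends of each are limits. Going by these compounds alone, what compound 4 adds is the first comparison with compound 1 that differs in one place: with the methoxy-bearing aromatic ring unchanged, a six-membered non-aromatic ring with nitrogen among its atoms replaces one with a second oxygen in the group, and the one readable step is an at least 91-fold higher number from compound 1 to compound 4 (1.96 log units; beyond the scatter).

The compounds shown leave open how far beyond their limits compound 2, compound 3 and compound 4 lie, and so whether this methoxy changes growth inhibition at all when the ring holds nitrogen. They also leave open whether a different group on this aromatic carbon, such as an amine or a carboxylic acid, or a methyl on the ring nitrogen, would give a value that the assay can read.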